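Demethylation of an aryl ether on a benzofuran ketone scaffold

A few compounds are considered here, and "the series" means these few. Any claim that something is new, unique, unknown or untested is made for them only; others in the source may bear on it.

Measured compounds:
Compound 1, `CCc1oc2cc(OC)ccc2c1C(=O)c1ccc(O)cc1`: 3920 nM
Compound 2, `CCc1oc2cc(O)ccc2c1C(=O)c1ccc(O)cc1`: 1130 nM
Compound 3, `CCc1cc2c(C(=O)c3cc(Br)c(O)c(Br)c3)c(OC)ccc2o1`: 358 nM

The three measured compounds were tested in an assay for inhibition of solute carrier family 22 member 12 (Homo sapiens), read by scintillation counting, with a stated time of 60 min; on this read-out higher numbers stand for weaker inhibition and lower numbers for stronger inhibition. Compound 1, `CCc1oc2cc(OC)ccc2c1C(=O)c1ccc(O)cc1`, gives 3920 nM, and compound 2, `CCc1oc2cc(O)ccc2c1C(=O)c1ccc(O)cc1`, gives 1130 nM. The change between them, (hydrogen in place of methyl on an oxygen on an aromatic ring), made a step of a 3.5-fold lower number from compound 1 to compound 2 (0.54 log units; beyond the scatter). Compound 3, `CCc1cc2c(C(=O)c3cc(Br)c(O)c(Br)c3)c(OC)ccc2o1`, gives 358 nM, the lowest number of the three; how its core differs from that of compound 1 is not broken down here.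

Compound 4, `CCc1cc2c(C(=O)c3cc(Br)c(O)c(Br)c3)c(O)ccc2o1`, has not yet been measured. It differs from compound 3 by hydrogen in place of methyl on an oxygen on an aromatic ring, the same change that separates compound 1 from compound 2. Because compound 2 reached 1130 nM through that change, a comparable step, a 3.4-fold lower number from compound 3 to compound 4 (0.53 log units; beyond the scatter), is expected for compound 4. Compound 4 is therefore estimated at 105 nM, most likely between 40 nM and 300 nM.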

Compound 4, half-maximal inhibitory concentration: 83 nM
The estimate for compound 4 lay 1.3-fold (0.10 log units) above the measured number; measured number inside the range.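

In this assay the change from methoxy to hydroxy on the second core gave a 4.3-fold lower number from compound 3 to compound 4 (0.63 log units; beyond the scatter) and so went the same way as on the first core. The two steps cannot be told apart in size, so the change carried over between these two cores: the same change on two cores in this assay, a 3.5-fold lower number (0.54 log units; beyond the scatter) from compound 1 to compound 2 and a 4.3-fold lower number (0.63 log units; beyond the scatter) from compound 3 to compound 4, 1.2-fold (0.09 log units) apart, within the scatter of two such steps. For the compounds shown here, this agreement rests on only two cores; it does not show that the step would hold on any other core, nor does it explain why the hydroxy compounds give the lower numbers.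

The compounds shown leave open what an ethyl group or a longer chain on that oxygen would do. They also leave open whether an amine or a carboxylic acid could take the place of the hydroxy group.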